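The source may hold more compounds than are shown below. What is called first, only, known or untested is meant among the compounds shown, and "the series" means these compounds.

Working notes on the series. The shared core is carried by three compounds: compound 1 `ClCc1ccc(Cn2cnc3c(Cl)ncnc32)cc1`, compound 2 `ClCc1ccccc1Cn1cnc2c(Cl)nc(Cl)nc21` and compound 3 `ClCc1ccccc1Cn1cnc2c(Cl)ncnc21`. In a functional assay on SW-620 cells (Homo sapiens) for cytotoxicity, read by sulforhodamine B assay, with a stated time of 48 h (a higher number here means that more compound is tolerated, a lower number that less compound is tolerated), compound 1 is reported as "not determined" (no result reported); no number is given for it. In this assay, among the measured compounds shown here, compound 2 gives 810 nM, which is the only figure in hand for the series, so compound 2 stands alone and no step between measured compounds can be drawn.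

Compound 3 is not yet measured. The change from compound 2 to compound 3 is hydrogen in place of chloro on an aromatic carbon, the place being the carbon between two ring nitrogen atoms of the six-membered ring. The chloromethyl-bearing benzyl part is untouched.

For the measured compounds named here, with no measured step to lean on, the expectation rests on the single value of compound 2 in this assay. The step is expected to be modest, towards more compound tolerated, of the size a 1.9-fold higher number from compound 2 to compound 3 (0.27 log units; within the scatter), and not clearly beyond the scatter. For compound 3 in this assay the estimate is 1500 nM, with a range from 500 nM to 5000 nM.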

Compound 3, concentration lethal to 50% of the cells: 26300 nM
Compound 3: the middle estimate sits 18-fold (1.24 log units) below what was measured; measured number outside the range, above it.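

In this assay, hydrogen in place of chloro on the aromatic carbon between two ring nitrogen atoms gives a 32-fold higher number from compound 2 to compound 3 (1.51 log units; beyond the scatter), so this position is far from silent. With the chloromethyl-bearing benzyl part and the remaining chloro group unchanged, this one replacement carries the whole step, and more compound is tolerated once the chloro has left. Compound 2 alone could not show which part of it mattered, whereas this first measured step ties a large change in the read-out to this single place, though nothing at hand bears on the reason for its size.

From the compounds shown here alone, it remains open whether another group on this carbon, such as an amine, a methoxy group or a methyl group, would stay close to compound 2, move towards compound 3, or fall elsewhere. Going by these compounds, it is equally open whether the same replacement would shift the number as far on a different benzyl part, for instance one carrying hydroxymethyl in place of chloromethyl.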